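The source may report more compounds than this note shows. Statements on the series, on what has been measured and on what is new or still open speak of the compounds shown alone.

Measured so far:
- compound 1, `O=C(O)[C@@H]1CCCN1C(=O)CN(c1nc(Cl)nc2[nH]cnc12)C1CC1`: in a functional assay on the whole organism (Tail, strain ICR) with Mus musculus as the target, in the tail flick test, with a stated time of 150 min, at a dose of 25 umol/kg by the oral route (on this read-out lower numbers stand for a weaker effect and higher numbers for a stronger effect at the one dose given), compound 1 gives 7.29%
- compound 2, `O=C(CN(c1ncnc2c1ncn2C1CCCCO1)C1CC1)N[C@@H](CCC(=O)OCc1ccccc1)C(=O)OCc1ccccc1`: in this assay compound 2 gives 14.1%

Within the data shown here, compound 2 stands at the larger of the two numbers, but the only other number, that of compound 1, sits close to it and the two lie within the usual scatter of each other, so on these data neither compound can be said to act differently from the other. Both read-outs are small for a single-dose test of this kind.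

Compound 3, `N=C(N)NCCC[C@H](NC(=O)CN(c1ncnc2c1ncn2C1CCCCO1)C1CC1)C(=O)OCc1ccccc1`, has not yet been measured in this assay. It differs from compound 2 in one place: a group of 5 heavy atoms (2 carbon, 3 nitrogen; no ring) in place of a group of 10 heavy atoms (8 carbon, 2 oxygen; one six-membered aromatic ring of carbon only), on a saturated chain carbon, three bonds along the chain from an amide-type nitrogen and a carbonyl carbon. Among the measured compounds shown here, no pair of measured compounds shows what such a change does here, so there is no measured step to lean on; the only guide is the weak response of compound 2 itself. The expected step is therefore small, a number 2.1 percentage points lower from compound 2 to compound 3 (within the scatter), and is not expected to go beyond the scatter in either direction. Compound 3 is expected to give about 12% in this assay, with a likely range from 2% to 28%.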

Compound 3, a percentage reported as activity, at one dose (the size of the read-out at that dose, not a potency): 19.6%
Beside the measured number, compound 3's estimate is 7.6 percentage points below it; the range from low to high includes it.
By their numbers in this assay, from the lowest: compounds 1, 2 and 3 (each within the scatter of the next, the first and the last beyond it).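

Among these compounds, this is the first measured step at this position, the saturated chain carbon three bonds along the chain from an amide-type nitrogen and a carbonyl carbon. In this assay replacing the benzyloxycarbonyl group with the group of 5 heavy atoms (2 carbon, 3 nitrogen; no ring) gives a number 5.5 percentage points higher from compound 2 to compound 3 (within the scatter) and so does not separate the two compounds at this single dose. Even a change this large, which removes the six-membered aromatic ring and brings in 3 hydrogen-bond donors where the old group had none, leaves the read-out inside the usual variation between repeated measurements, and nothing available explains the result.

From the compounds shown here alone, it remains open whether a simple amine, a carboxylic acid or a longer chain on this same carbon would give a response clearly beyond that variation. Also open, going by these compounds, is whether the step between these two groups would look the same at another dose or another time point.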